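The compounds below may be only part of what the source reports. "The series", "measured", "known", "first", "only" and "open" are said of these compounds alone.

Compound 1 `CCN(Cc1cccs1)C(=O)COc1ccc(C)cc1` gives 8 nM in an assay on HEK293 cells for agonist activity at transient receptor potential cation channel subfamily M member 8 (Homo sapiens), read by fluorescence and calcium flux, with a stated time of 15 min; a lower number here means that less compound is needed, a higher number that more compound is needed for the effect.
Compound 2 `Cc1ccc(OCC(=O)N(Cc2cccs2)c2ccn(C)n2)cc1` gives 855 nM in this assay.
Compound 3 `Cc1ccc(OCC(=O)N(Cc2cccs2)c2ccnn2C)cc1` gives 422 nM in this assay.

Of these three, compound 1 has the lowest number, so it needs the least material to produce the effect. The other two compounds differ from it only at the amide-type nitrogen, where the ethyl group is replaced by a ring: the step is a 110-fold higher number from compound 1 to compound 2 (2.03 log units; beyond the scatter) and a 53-fold higher number from compound 1 to compound 3 (1.72 log units; beyond the scatter), both large. Between the two ring variants the gap is smaller, a 2.0-fold lower number from compound 2 to compound 3 (0.31 log units; beyond the scatter).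

Compound 4 `CCN(Cc1cccs1)C(=O)COc1ccc(C#N)cc1` keeps the ethyl group and everything else of compound 1; the single difference is cyano in place of methyl on an aromatic carbon. None of the three measured steps touches this part of the molecule. All of them concern the amide-type nitrogen, so they offer no direct guide to what an exchange on the aromatic ring does. Within the data shown here, with no measured step bearing on it, the expectation for compound 4 is a change no larger than the usual scatter, a 1.8-fold higher number from compound 1 to compound 4 (0.24 log units; within the scatter), while the range is kept wide to reflect the lack of evidence. Compound 4 is estimated at 14 nM, within a range from 4 nM to 60 nM.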

Compound 4, half-maximal effective concentration: 1990 nM
For compound 4 the middle estimate is 140-fold (2.15 log units) below the measured one; the whole stated range lies below it.
By their numbers in this assay, from the lowest: compound 1; then compound 3; then compound 2; then compound 4.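

Among these compounds, until now, every step concerned the amide-type nitrogen, and this is the first reading from the other end of the molecule: on an aromatic carbon para to a large group, cyano in place of methyl gives a 250-fold higher number from compound 1 to compound 4 (2.40 log units; beyond the scatter) in this assay and compound 1 remains the reference point. The exchange is small on paper, with one more heavy atom, one hydrogen-bond acceptor gained, no ring and no net charge on either group, yet its step is large, just as the steps at the amide-type nitrogen were. So this place on the ring is as sensitive to change as the nitrogen, and a modest exchange here is enough to require far more compound for the effect, although nothing measured here explains why.

On these data alone, with only methyl and cyano to compare, it remains open whether methyl is specially suited to this place or cyano specially unsuited, and a chlorine atom, a methoxy group or a plain hydrogen there could help separate the two. As far as these compounds go, it is also open whether cyano would have the same effect on compounds 2 and 3, which carry a ring on the amide-type nitrogen.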